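A few compounds are considered here, and "the series" means these few. Any claim that something is new, unique, unknown or untested is made for them only; others in the source may bear on it.

Working notes on the shared core of compound 1 `O=C1Nc2ccc(C(=O)c3ccco3)cc2/C1=C/c1cc(F)c(O)c(F)c1`. In an assay on HeLa cells for inhibition of Kinesin-like protein KIF15 (Homo sapiens), read by microscopy, with stated times of 2 s and 20 s, tested at 750 nM (on this read-out higher numbers stand for more inhibition at the one concentration tested (going by the name of the read-out) and lower numbers for less inhibition), compound 1 gives 21%. Compound 2 `O=C1Nc2ccc(C(=O)c3ccco3)cc2/C1=C/c1cc(I)c(O)c(I)c1` gives 26% and compound 3 `O=C1Nc2ccc(C(=O)c3ccco3)cc2/C1=C/c1ccc(O)nc1` gives 26.5%; both sit within the scatter of compound 1, as a number 5 percentage points higher from compound 1 to compound 2 (within the scatter) and a number 5.5 percentage points higher from compound 1 to compound 3 (within the scatter) show, and between them a number 0.5 percentage points higher from compound 2 to compound 3 (within the scatter). Compound 4 `O=C1Nc2ccc(C(=O)c3ccco3)cc2/C1=C/c1ccnc(Cl)c1` is not yet measured; it differs from compound 1 by 2-chloropyridin-4-yl in place of 3,5-difluoro-4-hydroxyphenyl on a double-bonded chain carbon bound to a double-bonded ring carbon. Going by the values given here, the steps that bear on this are the two earlier exchanges of the group at the same place, both within the scatter, so a third exchange there is expected to give no step beyond the scatter in this assay, with a number 2 percentage points higher from compound 1 to compound 4 (within the scatter). Compound 4 is therefore estimated at 23%, range 8% to 40%.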

Compound 4, a percentage reported as inhibition, at one concentration (the size of the read-out at that concentration, not a potency): 15.8%
Estimate against measurement, compound 4: 7.2 percentage points above; the range from low to high includes it.
By their numbers in this assay, from the lowest: compounds 4, 1, 2 and 3 (each within the scatter of the next, the first and the last beyond it).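

At the double-bonded chain carbon bound to a double-bonded ring carbon, exchange of the group can move the number beyond the scatter in this assay: 2-chloropyridin-4-yl gives a number 10.7 percentage points lower from compound 3 to compound 4 (beyond the scatter) and a number 10.2 percentage points lower from compound 2 to compound 4 (beyond the scatter), yet there is only a number 5.2 percentage points lower from compound 1 to compound 4 (within the scatter). Compound 4, the only one here without a hydroxy group, separates from compound 2 and compound 3, while compound 1, which carries a hydroxy group, goes against a clean split. No measurement shown bears on the reason for these steps.

Open, going by these compounds, is whether the chlorine or the lost hydroxy group accounts for the lower number. Also open, on these data alone, is how an amine or a carboxylic acid would read at this place.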